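This account rests on a few compounds, and the source may have more. Where it says the series, first, only, none or still open, it means among the compounds named here.

Measured so far, in a functional assay on a cell-free system (Platelet, plasma, Homo sapiens) for inhibition; a lower number here means a stronger inhibitor, a higher number a weaker inhibitor:
- compound 1, `O=C(O)CCN1Cc2ccc(NC(=O)c3ccc(N4CCNCC4)cc3)cc2C1=O`, gives 540 nM
- compound 2, `O=C(O)CCN1Cc2ccc(NC(=O)c3ccc4c(c3)CNCC4)cc2C1=O`, gives 1100 nM

Compound 2 has the higher of the two numbers: its nearest neighbour is compound 1, whose number is lower by an amount beyond the usual scatter, so compound 2 is the weaker inhibitor of the pair. For the measured compounds named here, the two differ elsewhere in the structure, and no single-point step between them has been worked out, so their values can only be set side by side.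

Compound 3, `O=C(O)CCCN1Cc2ccc(NC(=O)c3ccc4c(c3)CNCC4)cc2C1=O`, differs from compound 2 in one place: carboxymethyl in place of carboxy on a saturated chain carbon, two bonds along the chain from an amide-type nitrogen in a ring. Read one bond further out, the 2-carboxyethyl chain on the ring nitrogen becomes a 3-carboxypropyl chain. Going by the values given here, nothing among the measured pair shows how this chain length matters, so the expectation rests on compound 2 alone, with the change in this assay expected to be small. The step of a 1.1-fold higher number from compound 2 to compound 3 (0.04 log units; within the scatter) is estimated to stay within the scatter. Compound 3 is expected to give about 1200 nM, with a range from 400 nM to 3500 nM.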

Compound 3, half-maximal inhibitory concentration: 330000 nM
For compound 3 the middle estimate is 280-fold (2.44 log units) below the measured one; the measured number lies above the stated range.
By their numbers in this assay, from the lowest: compound 1; then compound 2; then compound 3.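

In this assay, the carboxylic acid chain on the amide-type nitrogen in a ring proves highly sensitive to length: going from 2-carboxyethyl to 3-carboxypropyl gives a 300-fold higher number from compound 2 to compound 3 (2.48 log units; beyond the scatter). The earlier compounds shown here gave no view of this, as they differ elsewhere in the structure and share the same 2-carboxyethyl chain. The carboxy end is still present after the change, and the two groups compared have the same hydrogen-bond donor and acceptor counts and no net charge, so these counts do not separate the two compounds, and the data offer no measured explanation for a step of this size.

As far as these compounds go, what remains open is how the shorter carboxymethyl chain or a still longer chain would fare at this position, and whether an amide or an alcohol could stand in for the carboxylic acid at the end of the chain. It is also unknown whether the same lengthening would have as large an effect on the core of compound 1, which carries a different group at the other end of the molecule.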